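The source may report more compounds than this note shows. Statements on the series, on what has been measured and on what is new or still open speak of the compounds shown alone.

Working notes on the series, measured in a functional assay on NCI-H1993 cells (Homo sapiens) for inhibition, read by CCK-8 assay, with a stated time of 72 h; a lower number here means a stronger inhibitor, a higher number a weaker inhibitor:

- compound 1 `CCC(c1cc2cccnc2cc1F)n1cnc2ncc(-c3cnn(C)c3)nc21` gives "not determined" (no result reported)
- compound 2 `Cc1c(C(C)n2cnc3ncc(-c4cnn(C)c4)nc32)ccc2ncccc12` gives 206 nM
- compound 3 `CC(NC/N=C/c1cnn(C)c1)c1ccc2ncccc2c1` gives 197 nM

Among the compounds with values here, only two numbers are available. Compound 3 at 197 nM and compound 2 at 206 nM lie within the scatter of each other, so these data do not separate them. Compound 1 has no number to compare.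

Compound 4 `CC(NC/N=C/c1cnn(CCO)c1)c1ccc2ncccc2c1` has not yet been measured. It differs from compound 3 by hydroxymethyl in place of hydrogen on a saturated chain carbon bound to an aromatic nitrogen, which can also be read as methyl to 2-hydroxyethyl. Within the data shown here, no measured pair shows the effect of this change, so the expectation rests on compound 3 at 197 nM and carries wide uncertainty. No step beyond the scatter is expected in this assay, in either direction. The estimated step is a 1.0-fold higher number from compound 3 to compound 4 (0.01 log units; within the scatter). For compound 4 the expected value is 200 nM, with an estimated range from 70 nM to 600 nM.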

Compound 4, half-maximal inhibitory concentration: 148 nM
Compound 4: the middle estimate sits 1.4-fold (0.13 log units) above what was measured; the range from low to high includes it.
By their numbers in this assay, from the lowest: compounds 4, 3 and 2 (each within the scatter of the next).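

Within the data shown here, this is the only pair that differs in one place, and it gives a direct reading of this position: in this assay, hydroxymethyl in place of hydrogen on a saturated chain carbon bound to an aromatic nitrogen gives a 1.3-fold lower number from compound 3 to compound 4 (0.12 log units; within the scatter). The position therefore tolerates the change from methyl to 2-hydroxyethyl, with no step beyond the scatter in either direction, and the two compounds are not separated by this assay. Nothing measured alongside these compounds speaks to the reason for this result.

As far as these compounds go, whether a longer chain, a terminal amine or a carboxylic acid at this place would also stay within the scatter remains open, since a single step sets no trend. From the compounds shown here alone, it is also open whether 2-hydroxyethyl would give a similar result on the core of compound 2.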